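The compounds below may be only part of what the source reports. "The series", "measured", "known", "first", "only" and "open" are said of these compounds alone.

Of the compounds shown here, three of one series have been tested in an assay on isolated protein for binding affinity to 5-hydroxytryptamine receptor 1E (Homo sapiens) (a lower number here means a stronger inhibitor, a higher number a weaker inhibitor), and a fourth awaits its result. Compound 1 `Cc1ccc(-c2n[nH]cc2N2CCCNCC2)cc1`, compound 2 `Fc1ccc(-c2n[nH]cc2N2CCCNCC2)cc1` and compound 3 `Fc1ccc(-c2n[nH]cc2N2CCNCC2)cc1` share a core, and compound 4 `Cc1ccc(-c2n[nH]cc2N2CCNCC2)cc1` completes the set. In this assay compound 1 gives > 10000 nM, which is a limit of the assay and not a number. In this assay compound 2 gives > 10000 nM, again a limit of the assay rather than a number. In this assay compound 3 gives > 10000 nM, likewise a limit of the assay. All three values therefore sit at the limit of > 10000 nM in this assay, at which 3 of the 3 values shown sit.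

Compound 2 differs from compound 1 by methyl in place of fluoro on an aromatic carbon. The step that the two limits leave unreadable from compound 2 to compound 1 cannot be read, since both values are limits. The cores of compound 2 and compound 3 differ, but the difference between the two cores is not broken down here.

Compound 4 differs from compound 3 by methyl in place of fluoro on an aromatic carbon, the same change as that from compound 2 to compound 1, made at a place described in the same words. This change occurs twice among the compounds shown.

Since compound 3 gives > 10000 nM, a limit, and since the same change left compound 1 at > 10000 nM, also a limit, the step from compound 3 to compound 4 is expected to be a step that the limit leaves unreadable from compound 3 to compound 4. Compound 4 is thus estimated at 20000 nM in this assay, with the likely outcome that only a limit is again reported, and the measurement will tell.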

Compound 4, inhibition constant: > 10000 nM
Compound 4 ended at the assay's limit; the forecaster's own chance of this, stated with the estimate: 85%; the middle value is on the limit's open side.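

In this assay, for the compounds shown here, compound 4 gives > 10000 nM, again a limit of the assay and not a number, so the step from compound 3 to compound 4 cannot be read, and no new step comes from this result. All four compounds stand at the same point: the limit of > 10000 nM in this assay, at which 4 of the 4 values shown sit.

The compounds shown leave open what their actual affinities are, and whether methyl in place of fluoro or the difference between the cores changes them at all.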